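From ethoxy to propoxy in compound 4

A few compounds are considered here, and "the series" means these few. Any claim that something is new, unique, unknown or untested is made for them only; others in the source may bear on it.

Compound 1 `Oc1c(CN2CCCCC2)ccc2cccnc12` gives 2690 nM; 2750 nM (2 entries) in a functional assay on MES-SA/Dx5 cells (Homo sapiens) for inhibition, with a stated time of 72 h, in the presence of a further agent that is not named here; a lower number here means a stronger inhibitor, a higher number a weaker inhibitor
Compound 2 `COCc1cc(CN2CCCCC2)c(O)c2ncccc12` gives 7590 nM in this assay
Compound 3 `CCOCc1cc(CN2CCCCC2)c(O)c2ncccc12` gives 7080 nM in this assay

On these numbers, compound 3 (7080 nM) lies within the scatter of compound 2 (7590 nM), while both show higher numbers than compound 1 (2690 nM; 2750 nM (2 entries)). The next structure, compound 4 `CCCOCc1cc(CN2CCCCC2)c(O)c2ncccc12`, differs from compound 3 by a single change (methyl in place of hydrogen on a saturated chain carbon, two bonds along the chain from an oxygen on a saturated carbon): methyl in place of hydrogen on a saturated chain carbon, two bonds along the chain from an oxygen on a saturated carbon, which reads as ethoxy to propoxy. Among the compounds with values here, one measured step bears on this change. It also puts methyl in place of hydrogen, there on a saturated chain carbon bound to an oxygen on a saturated carbon, and its size (a 1.1-fold lower number from compound 2 to compound 3 (0.03 log units; within the scatter)) stays within the scatter. With that single step as the guide, no change beyond the scatter is expected in this assay for the further methyl. Compound 4 is expected at about 7000 nM, with an estimated range from 3800 nM to 12500 nM ( the range is wide because it rests on one step ). That estimate means an expected step (a 1.0-fold lower number from compound 3 to compound 4 (0.00 log units; within the scatter)) of no real size.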

Compound 4, half-maximal inhibitory concentration: 2400 nM
Compound 4: the middle estimate sits 2.9-fold (0.46 log units) above what was measured, and the stated range ends above it.
By their numbers in this assay, from the lowest: compound 4; then compounds 3 and 2 (each within the scatter of the next).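

In this assay, the ethoxy to propoxy change gives a 3.0-fold lower number from compound 3 to compound 4 (0.47 log units; beyond the scatter), whereas the methyl placed on a saturated chain carbon bound to an oxygen on a saturated carbon gave a 1.1-fold lower number from compound 2 to compound 3 (0.03 log units; within the scatter). Across the whole extension, ethyl in place of hydrogen on that same carbon gives a 3.2-fold lower number from compound 2 to compound 4 (0.50 log units; beyond the scatter), so the response along these three chains is uneven, and a step beyond the scatter appears only on reaching propoxy. Compound 4 rests on a single entry, and the one compound shown with repeat entries gives a sense of how closely this assay repeats: the several entries of compound 1 in this assay, 2690 nM; 2750 nM (2 entries)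

From the compounds shown here alone, whether the lower number carries on with a longer chain such as butoxy, or holds when the chain ends in an amine or a carboxylic acid, stays open. The compounds shown also do not tell what lies behind the uneven steps along the chain.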